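Chalcone guanylhydrazones: aryl exchange and ear inhibition

A few compounds are considered here, and "the series" means these few. Any claim that something is new, unique, unknown or untested is made for them only; others in the source may bear on it.

Compound 1 `Cc1ccc(C(=O)/C=C/c2ccc(/C=N/NC(=O)c3ccccc3)cc2)c(C)c1` gives 0.18% in a functional assay on the whole organism (Ear) for inhibition, with Mus musculus as the target, with a stated time of 30 min, at a dose of 100 mg/kg by the intraperitoneal route; a higher number here means more inhibition at the dose given (going by the name of the read-out), a lower number less inhibition.
Compound 2 `N=C(N)N/N=C/c1ccc(/C=C/C(=O)c2ccc(Cl)cc2)cc1` gives 56.4% in this assay.
Compound 3 `COc1ccc(C(=O)/C=C/c2ccc(/C=N/NC(=N)N)cc2)cc1` gives 57.2% in this assay.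

Compound 3 and compound 2 lie within the scatter of each other, a number 0.8 percentage points higher from compound 2 to compound 3 (within the scatter), and both sit well above compound 1. Compound 4 `Cc1ccc(C(=O)/C=C/c2ccc(/C=N/NC(=N)N)cc2)c(C)c1` differs from compound 3 by 2,4-dimethylphenyl in place of 4-methoxyphenyl on a carbonyl carbon. Among the measured compounds shown here, the only measured step on the aryl side of the carbonyl is the one from chloro to methoxy, which stayed within the scatter; compound 1 carries the same 2,4-dimethylphenyl but also a different hydrazone, so its low value cannot be assigned to the aryl group alone. A modest drop is therefore expected in this assay, estimated as a number 12.2 percentage points lower from compound 3 to compound 4 (beyond the scatter). Compound 4 is expected to give 45%, between 10% and 65%.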

Compound 4, a percentage reported as inhibition, in the whole organism at one dose (the size of the read-out at that dose, not a potency): 64.2%
The estimate for compound 4 lay 19.2 percentage points below the measured number, and the stated range covers the measured number.
By their numbers in this assay, from the lowest: compound 1; then compounds 2, 3 and 4 (each within the scatter of the next).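

Placing 2,4-dimethylphenyl on the carbonyl carbon keeps the read-out in this assay within the scatter of both earlier aryl variants, with a number 7 percentage points higher from compound 3 to compound 4 (within the scatter) and a number 7.8 percentage points higher from compound 2 to compound 4 (within the scatter). With that aryl group held constant, exchange on the amine nitrogen gives a number 64 percentage points higher from compound 1 to compound 4 (beyond the scatter), so the low value of compound 1 follows the group on that nitrogen rather than the aryl group. Nothing available explains either result. Still open, going by these compounds, is whether an aryl group carrying a carboxylic acid or an amine on the carbonyl carbon would hold this level. Also open, on these data alone, is whether a longer chain on the amine nitrogen would.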